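Swapping chloro for trifluoromethoxy on one aromatic carbon

A few compounds are considered here, and "the series" means these few. Any claim that something is new, unique, unknown or untested is made for them only; others in the source may bear on it.

- Compound 1 `CC/C(O)=C(\C#N)C(=O)Nc1ccc(-c2ccc(F)cc2)c(C(=O)OC)c1`: 2000 nM
- Compound 2 `CC/C(O)=C(\C#N)C(=O)Nc1ccc(-c2cccc(Cl)c2)c(C(=O)OC)c1`: 34000 nM

In a functional assay on PBMC cells (Homo sapiens) for inhibition, read by ELISA, BrdU incorporation and thymidine incorporation, with a stated time of 72 h (a lower number here means a stronger inhibitor, a higher number a weaker inhibitor), compound 2 gives the higher of the two numbers, 34000 nM, so it is the weaker inhibitor. Compound 3 `CC/C(O)=C(\C#N)C(=O)Nc1ccc(-c2cccc(OC(F)(F)F)c2)c(C(=O)OC)c1` carries trifluoromethoxy in place of chloro on an aromatic carbon, meta to a large group: trifluoromethoxy in place of chloro on an aromatic carbon. Among the measured compounds shown here, the only measured step, a 17-fold higher number from compound 1 to compound 2 (1.23 log units; beyond the scatter), was large, but it exchanged 4-fluorophenyl for 3-chlorophenyl, a different change. For the measured compounds named here, no measured step tests this swap, so no shift beyond the scatter is expected, and the estimated step is a 1.1-fold lower number from compound 2 to compound 3 (0.05 log units; within the scatter). In this assay the estimate for compound 3 is 30000 nM, with an expected range from 9000 nM to 100000 nM.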

Compound 3, half-maximal inhibitory concentration: 37000 nM
Estimate against measurement, compound 3: 1.2-fold (0.09 log units) below; the range from low to high includes it.
By their numbers in this assay, from the lowest: compound 1; then compounds 2 and 3 (each within the scatter of the next).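

Putting trifluoromethoxy in place of chloro gives a 1.1-fold higher number from compound 2 to compound 3 (0.04 log units; within the scatter) in this assay. At this aromatic carbon, meta to a large group, the two groups therefore cannot be told apart, although trifluoromethoxy has 5 heavy atoms and 1 hydrogen-bond acceptor, while chloro has 1 heavy atom and no acceptor. Nothing available explains why these two groups read alike. Still open, as far as these compounds go, is whether an amine or a carboxylic acid at this carbon would give a clearly different number. From the compounds shown here alone, with only chloro and trifluoromethoxy compared directly here, the tolerance of this position for other groups remains unknown.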